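This account rests on a few compounds, and the source may have more. Where it says the series, first, only, none or still open, it means among the compounds named here.

Working notes on the series, read in an ADME assay on L1210 cells (Mus musculus) for cytotoxicity, with a stated time of 48 h; a lower number here means a stronger inhibitor, a higher number a weaker inhibitor. Compound 1 (`CC1=CCC[C@](C)(CC/C(C)=C/CC2=C(O)C(=O)C=C(N[C@@H](C(=O)O)[C@@H](C)O)C2=O)[C@@H]1C`) gives > 10 ug/mL, which is a limit of the assay and not a number. Among the compounds with values here, compound 2 (`C=C1[C@H](C)CCC[C@]1(C)CC/C(C)=C/CC1=C(O)C(=O)C=C(N[C@@H](C(=O)O)[C@H](C)O)C1=O`) gives 4.6 ug/mL, the only actual number so far. Compound 3 (`C=C1[C@H](C)CCC[C@]1(C)CC/C(C)=C/CC1=C(O)C(=O)C=C(NCC(=O)O)C1=O`) has not yet been measured in this assay. Relative to compound 2, it carries hydrogen in place of 1-hydroxyethyl on a saturated chain carbon bound to an amine nitrogen and a carbonyl carbon. Within the data shown here, no measured pair differs in one place, so this change has no direct precedent here. The reference point is compound 2 at 4.6 ug/mL. The step of a 1.1-fold higher number from compound 2 to compound 3 (0.04 log units; within the scatter) is expected to stay within the scatter, with no clear direction. Compound 3 is estimated at 5 ug/mL, with an expected range of 2 ug/mL to 12 ug/mL.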

Compound 3, half-maximal inhibitory concentration: 4 ug/mL
The estimate for compound 3 lay 1.3-fold (0.10 log units) above the measured number, within the range that was stated.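

In this assay, within the data shown here, the pair offers the first reading at this position, with hydrogen in place of 1-hydroxyethyl on a saturated chain carbon bound to an amine nitrogen and a carbonyl carbon: a 1.2-fold lower number from compound 2 to compound 3 (0.06 log units; within the scatter). The 1-hydroxyethyl group and its defined stereocentre are therefore not needed for compound 3 to stay within the scatter of compound 2. Nothing measured here gives a cause for this step.

With only hydrogen and 1-hydroxyethyl shown on this carbon, it remains open whether a larger group such as benzyl, or a chain ending in an amine such as 4-aminobutyl, would hold the value. Compound 1 gives > 10 ug/mL, a limit of the assay and not a number, and it differs from compound 2 in more than one place, so it adds nothing on this position.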